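The source may hold more compounds than are shown below. What is called first, only, known or untested is meant among the compounds shown, and "the series" means these compounds.

In a functional assay on U-373MG ATCC cells for inhibition, with U373 MG (Homo sapiens) as the target, read by MTT assay, with a stated time of 7 days (a higher number here means a weaker inhibitor of growth, a lower number a stronger inhibitor of growth), compound 1 `C#CCn1nnc2c(C(N)=O)ncn2c1=O` gives 37600 nM. Compound 2 `NC(=O)c1ncn2c(=O)n(Cc3ccccc3)nnc12` gives > 50000 nM, which is a limit of the assay and not a number. Compound 3 `COc1cccc(Cn2nnc3c(C(N)=O)ncn3c2=O)c1` gives > 50000 nM, also a limit. That places compound 3 at the limit of > 50000 nM in this assay, at which 2 of the 3 values shown sit, with no number of its own to start from.

Compound 4 `COc1ccc(Cn2nnc3c(C(N)=O)ncn3c2=O)cc1OC` adds one change to compound 3: methoxy in place of hydrogen on an aromatic carbon. Among the measured compounds shown here, two measured steps bear on it. For the measured compounds named here, the same kind of replacement, methoxy in place of hydrogen on an aromatic carbon, gave a step that the two limits leave unreadable from compound 2 to compound 3, so the closest precedent has no readable size. The replacement of ethynyl by phenyl is a different change, and it gave an at least 1.3-fold higher number from compound 1 to compound 2 (0.12 log units; that floor lies within the scatter). Neither step supports a shift in a known direction in this assay.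

The expected result is a step that the limit leaves unreadable from compound 3 to compound 4, which means no step beyond the scatter. For compound 4 the estimate is 55000 nM, with an expected range of 25000 nM to 110000 nM, and a report of only a limit is the likeliest outcome.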

Compound 4, concentration for 50% growth inhibition: > 50000 nM
Compound 4: no number, only a limit; the forecaster's own chance of this, stated with the estimate: 85%; the middle value is on the limit's open side.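

In this assay compound 4 gives > 50000 nM, a limit of the assay and not a number. Among the compounds shown here, compound 3 also stands at a limit, so no step between compound 3 and compound 4 can be read. The compounds shown leave open whether methoxy in place of hydrogen on an aromatic carbon changes growth inhibition at all, as most values rest on one limit: the limit of > 50000 nM in this assay, at which 3 of the 4 values shown sit.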